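The source may hold more compounds than are shown below. What is called first, only, known or untested is meant among the compounds shown, and "the series" means these compounds.

Measured so far:
Compound 1, `O=C(CI)NCCCCCCCCNc1ncnc2c1ncn2[C@@H]1O[C@H](COP(=O)(O)OP(=O)(O)OP(=O)(O)O)[C@@H](O)[C@H]1O`: 35%
Compound 2, `O=C(CI)NCCCCNc1ncnc2c1ncn2[C@@H]1O[C@H](COP(=O)(O)OP(=O)(O)OP(=O)(O)O)[C@@H](O)[C@H]1O`: 0%

Both numbers come from an assay on isolated protein for inhibition of hexokinase-1 (Rattus norvegicus), with a stated time of 6 h, tested at 10 mM; a higher number here means more inhibition at the concentration tested (going by the name of the read-out), a lower number less inhibition. Going by the values given here, compound 2 stands at the bottom of the two: in this assay compound 2 gives 0%, and the only measured step, a number 35 percentage points lower from compound 1 to compound 2 (beyond the scatter), is a large drop beyond the usual scatter. That step shortened the chain between the nitrogen on the aromatic ring and the iodoacetamide, and the inhibition fell away.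

Compound 3, `O=C(CI)NCCCCCC(=O)NCCCCNc1ncnc2c1ncn2[C@@H]1O[C@H](COP(=O)(O)OP(=O)(O)OP(=O)(O)O)[C@@H](O)[C@H]1O`, is not yet measured. Its change from compound 2 is 4-(((iodomethyl)carbonyl)amino)butyl in place of iodo on a saturated chain carbon bound to a carbonyl carbon. The chain is thus lengthened again, this time with an amide set into it, so the iodoacetamide sits well out from the shared core as it does in compound 1. The step from compound 1 to compound 2 bears on this: it shows that a longer chain went with clearly more inhibition. On these data alone, a rise in this assay of similar direction is therefore expected for compound 3, though the inserted amide is untested, so the size is uncertain. Compound 3 is estimated at 25% (range 5% to 45%), an expected step of a number 25 percentage points higher from compound 2 to compound 3 (beyond the scatter).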

Compound 3, a percentage reported as inhibition, at one concentration (the size of the read-out at that concentration, not a potency): 0%
Estimate against measurement, compound 3: 25 percentage points above; the measured number lies below the stated range.
By their numbers in this assay, from the lowest: compounds 2 and 3 (each within the scatter of the next); then compound 1.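

In this assay, replacing iodo with 4-(((iodomethyl)carbonyl)amino)butyl, on a saturated chain carbon bound to a carbonyl carbon, gives no change at the digits printed from compound 2 to compound 3 (within the scatter). The earlier step from compound 1 tied a shorter chain to a loss of inhibition, but this result shows that adding length back to the chain of compound 2, with an amide set into it, does not by itself restore a measurable reading at this position: chain length alone is not a sufficient description of what matters here, and compound 3 goes against any simple rule that a longer chain gives more inhibition. Nothing available here explains why the added chain made no difference.

The compounds shown leave open whether the inserted amide or the extra length accounts for this result, since the two changes arrive together in compound 3. An unbroken saturated carbon chain of the same length, or a chain with an ether oxygen where the amide stands, would help separate those two possibilities.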